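A few compounds are considered here, and "the series" means these few. Any claim that something is new, unique, unknown or untested is made for them only; others in the source may bear on it.

Working notes on the hydrazone series in a functional assay on the whole organism for inhibition, with Rattus norvegicus as the target; on this read-out higher numbers stand for an effect only at larger amounts of compound and lower numbers for an effect already at smaller amounts. Compound 1 `CC1CC/C(=N\Nc2cccc(Br)c2)c2ncc(C(=O)O)c(=O)n21` gives only a limit in this assay, > 320 umol/kg. Compound 2 `CC1CC/C(=N\Nc2cccc(I)c2)c2ncc(C(=O)O)c(=O)n21` gives 1000 umol/kg in this assay. Compound 3 `COc1ccc(N/N=C2\CCC(C)n3c2ncc(C(=O)O)c3=O)cc1` gives 7.6 umol/kg in this assay and so holds the lowest of the two numbers; the nearest value is that of compound 2, with the step of a 130-fold lower number from compound 2 to compound 3 (2.12 log units; beyond the scatter). The step of an at least 42-fold lower number from compound 1 to compound 3 (1.62 log units; beyond the scatter) runs in the same direction, while the step that the limit leaves unreadable from compound 1 to compound 2 cannot be sized because compound 1 sits at the limit of > 320 umol/kg in this assay, at which 1 of the 3 values shown sits.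

Compound 4 `CCCCc1ccc(N/N=C2\CCC(C)n3c2ncc(C(=O)O)c3=O)cc1` is the next member. It differs from compound 3 in one place: butyl in place of methoxy on an aromatic carbon

Both measured steps exchange a 3-bromophenyl or 3-iodophenyl for a 4-methoxyphenyl on the amine nitrogen and were large; neither touches the methoxy itself, so they set only a loose frame for the change to butyl. For the measured compounds named here, with no closer precedent, the expected step is at most modest, its direction uncertain, with a lean toward a higher number. Compound 4 is therefore estimated at 15 umol/kg in this assay, within a range of 3 umol/kg to 80 umol/kg, which means an expected step of a 2.0-fold higher number from compound 3 to compound 4 (0.30 log units; within the scatter).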

Compound 4, dose for 50% inhibition: 100 umol/kg
Compound 4: middle estimate off by 6.7-fold (0.82 log units), on the low side; measured number outside the range, above it.
By their numbers in this assay, from the lowest: compound 3; then compound 4; then compound 2.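

In this assay, butyl in place of methoxy on an aromatic carbon, para to a large group, gives a 13-fold higher number from compound 3 to compound 4 (1.12 log units; beyond the scatter). The earlier steps shown here exchanged the whole substituted phenyl on the amine nitrogen, whereas this step keeps the phenyl and changes only the group at this one place, which shows that this group alone can move the number by a large step. The change replaces a group with 2 heavy atoms and 1 hydrogen-bond acceptor by one with 4 heavy atoms and 0 hydrogen-bond acceptors, but the data shown hold no measured property that bears on this step.

From the compounds shown here alone, with only methoxy and butyl compared at this place, it stays open whether the number climbs steadily with chain length, which an ethyl or a propyl group there would help to settle. Going by these compounds, it is equally open whether the low number of compound 3 is specific to methoxy or is shared by other small groups, such as a hydroxyl, an amine or a chlorine atom, at the same place.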